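Removal of the bromoacrylamide from compound 2

The source may hold more compounds than are shown below. What is called first, only, known or untested is meant among the compounds shown, and "the series" means these compounds.

Measured compounds in a functional assay on HeLa cells (Homo sapiens) for cytotoxicity, read by cell counting, with a stated time of 4 days; a lower number here means a stronger inhibitor, a higher number a weaker inhibitor:
compound 1 `CC(C)(C)c1ccc(CN2C(=O)S/C(=C\c3cccc(N)c3)C2=O)cc1`: 145000 nM
compound 2 `C=C(Br)C(=O)Nc1cccc(/C=C2\SC(=O)N(Cc3ccc(C(F)(F)F)cc3)C2=O)c1`: 820 nM
compound 3 `C=C(Br)C(=O)Nc1cccc(/C=C2\SC(=O)N(Cc3cccc(Cl)c3)C2=O)c1`: 2500 nM

In this assay compound 2 gives the lowest number of the three. Its nearest neighbour is compound 3, where the only difference is 3-chlorophenyl in place of 4-(trifluoromethyl)phenyl on the saturated chain carbon bound to the ring nitrogen, and that step reads a 3.0-fold higher number from compound 2 to compound 3 (0.48 log units; beyond the scatter). Compound 1 lies far above both.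

Compound 4 `Nc1cccc(/C=C2\SC(=O)N(Cc3ccc(C(F)(F)F)cc3)C2=O)c1` is compound 2 with the change (hydrogen in place of (1-bromoethenyl)carbonyl on a nitrogen on an aromatic ring). Among the measured compounds shown here, no measured step covers exactly this change. For the measured compounds named here, the only guide is compound 1, which also carries a free amino group on the aromatic ring but differs from compound 2 in a second place as well, the group on the benzylic carbon. The values of compound 1 and compound 2 show a very wide gap, far larger than the step from compound 2 to compound 3. Most of that gap is therefore attributed to the amino group because compound 1 gives 145000 nM where compound 2 gives 820 nM, and compound 4 is expected to move strongly toward the value of compound 1.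

The step from compound 2 to compound 4 in this assay is estimated as a 120-fold higher number from compound 2 to compound 4 (2.09 log units; beyond the scatter). For compound 4 the estimated value is 100000 nM with a range of 20000 nM to 400000 nM.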

Compound 4, half-maximal inhibitory concentration: > 250000 nM
Compound 4 was reported as a limit (the forecaster's own chance of this, stated with the estimate: 25%); middle value at least 2.5-fold (0.39 log units) away from the limit.
By their numbers in this assay, from the lowest: compound 2; then compound 3; then compound 1. At a limit, above all of these: compound 4.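

In this assay, compound 4 is reported only as a limit and not as a number: the limit of > 250000 nM in this assay, at which 1 of the 4 values shown sits. With hydrogen in place of (1-bromoethenyl)carbonyl on a nitrogen on an aromatic ring, the series now has a comparison that differs in this one place, and it reads an at least 300-fold higher number from compound 2 to compound 4 (2.48 log units; beyond the scatter); the earlier link through compound 1 always carried a second difference as well. The other new comparison, trifluoromethyl in place of tert-butyl on an aromatic carbon, reads an at least 1.7-fold higher number from compound 1 to compound 4 (0.23 log units; that floor lies within the scatter), so it sets no order between the two free-amino compounds and gives no sign that this group changes the picture once the (1-bromoethenyl)carbonyl has gone.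

The compounds shown do not say which part of the (1-bromoethenyl)carbonyl accounts for the step, and a plain acetyl or acryloyl group on the same nitrogen would separate the carbonyl from the bromine and the double bond. On these data alone, whether tert-butyl and trifluoromethyl differ while the (1-bromoethenyl)carbonyl is in place also stays open, and a tert-butyl compound bearing that group would address it.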